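The compounds below may be only part of what the source reports. "The series", "measured", "known", "first", "only" and "open" are said of these compounds alone.

Compound 1 `COc1ccc(N(C)c2nc(C)nc3ccccc23)cc1C(=O)OCCC[Se]C#N` - 1140 nM
Compound 2 `COc1ccc(N(C)c2nc(C)nc3ccccc23)cc1C(=O)NCC[Se]C#N` - 1170 nM

Among the compounds with values here, in a functional assay on RKO cells (Homo sapiens) for inhibition, read by MTT assay, with a stated time of 48 h (a higher number here means a weaker inhibitor, a lower number a stronger inhibitor), compound 2 (1170 nM) cannot be told apart from the only other measured compound, and the single measured step lies within the scatter (a 1.0-fold higher number from compound 1 to compound 2 (0.01 log units; within the scatter)). Compound 3 `COc1ccc(N(C)c2nc(C)nc3ccccc23)cc1[Se]C` brings a far bigger change (a group of 2 heavy atoms (1 carbon, 1 selenium; no ring) in place of a group of 8 heavy atoms (4 carbon, 2 nitrogen, 1 oxygen, 1 selenium; no ring), on an aromatic carbon), on an aromatic carbon, ortho to a methoxy group. The measured step bears on this only weakly: it altered a group on a carbonyl carbon and kept that carbonyl, whereas here the whole group goes. Within the data shown here, no measured compound carries so small a group, so the direction is a judgement rather than a trend. The expected step is a 9.8-fold lower number from compound 2 to compound 3 (0.99 log units; beyond the scatter), with much uncertainty. Compound 3 is estimated at about (120 nM), within an expected range (10 nM to 1500 nM).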

Compound 3, half-maximal inhibitory concentration: 11 nM
Estimate against measurement, compound 3: 11-fold (1.04 log units) above; low and high end bracket the measured number.
By their numbers in this assay, from the lowest: compound 3; then compounds 1 and 2 (each within the scatter of the next).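

In this assay, the group on this aromatic carbon, ortho to a methoxy group, matters far more than the first two compounds could show: altering the chain beyond the carbonyl gave no readable change, but replacing the whole group with the much smaller selenium-methyl group gives a large drop in the number (a 110-fold lower number from compound 2 to compound 3 (2.03 log units; beyond the scatter)). The other longer group gives a step of similar size (a 100-fold lower number from compound 1 to compound 3 (2.02 log units; beyond the scatter)), so compound 3 stands well apart from both carbonyl-bearing compounds, whichever chain they carry. Nothing measured here explains this large step.

The carbonyl, the chain and the nitrile all leave together, so the compounds shown cannot separate their contributions. A nitrile in place of the methyl on selenium, or a longer alkyl chain on selenium, would begin to separate them.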